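This account rests on a few compounds, and the source may have more. Where it says the series, first, only, none or still open, it means among the compounds named here.

Compound 1 `CCCCCCCCCCc1ccc(-c2noc(C3CCNC3)n2)cc1`: 26% in an assay on HeLa cells for inhibition of sphingosine-1-phosphate transporter SPNS2 (Mus musculus), read by LC-MS, tested at 2 uM; on this read-out lower numbers stand for less inhibition and higher numbers for more inhibition at the one concentration tested (going by the name of the read-out). Compound 2 `CCCCCCCCCCc1ccc(-c2noc(-c3cccc(CN)c3)n2)cc1`: 2% in this assay.

Among the measured compounds shown here, compound 2 stands lowest of the two numbers; the only measured step, a number 24 percentage points lower from compound 1 to compound 2 (beyond the scatter), separates it from compound 1. Compound 3 `CCCCCCCCCCc1ccc(-c2noc(CC(O)CNCC)n2)cc1` is still to be measured. For the measured compounds named here, the change 3-(ethylamino)-2-hydroxypropyl in place of 3-(aminomethyl)phenyl on an aromatic carbon has no direct counterpart among the measured pairs, so that single step is the only guide, and it shows that replacing a non-aromatic amine-bearing group with an aromatic one lowered the number. The reverse direction is taken here, so a modest rise in this assay is expected, roughly a number 16 percentage points higher from compound 2 to compound 3 (beyond the scatter). Compound 3 is therefore estimated at 18%, within 0% to 40%.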

Compound 3, a percentage reported as inhibition, at one concentration (the size of the read-out at that concentration, not a potency): 5%
Beside the measured number, compound 3's estimate is 13 percentage points above it, within the range that was stated.
By their numbers in this assay, from the lowest: compounds 2 and 3 (each within the scatter of the next); then compound 1.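

In this assay the open-chain 3-(ethylamino)-2-hydroxypropyl group and the 3-(aminomethyl)phenyl group cannot be told apart on this aromatic carbon, with a number 3 percentage points higher from compound 2 to compound 3 (within the scatter). Removing the aromatic ring therefore does not by itself bring the number back, and set against the pyrrolidin-3-yl group, the open chain gives a number 21 percentage points lower from compound 1 to compound 3 (beyond the scatter). No measurement here explains these results.

As far as these compounds go, it remains open whether the higher number depends on the amine being held in a non-aromatic ring. A piperidin-4-yl or azetidin-3-yl group at this position would test that.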